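A few compounds are considered here, and "the series" means these few. Any claim that something is new, unique, unknown or untested is made for them only; others in the source may bear on it.

Measured compounds:
- compound 1, `O=C(Nc1ccc(Oc2ccnc3[nH]ccc23)c(F)c1)c1cc2cccnc2n(-c2ccc(F)c(Cl)c2)c1=O`: 310 nM
- compound 2, `O=C(Nc1ccc(Oc2ccnc3[nH]ccc23)c(F)c1)c1cc2cccnc2n(-c2ccc(Br)cc2F)c1=O`: 820 nM
- compound 3, `Cn1ccc2c(Oc3ccc(NC(=O)c4cc5cccnc5n(-c5ccc(F)c(Cl)c5)c4=O)cc3)ccnc21`: 1210 nM

All three numbers come from a functional assay on HT-29 cells (Homo sapiens) for antiproliferative activity, read by MTT assay, with a stated time of 72 h; a lower number here means a stronger inhibitor, a higher number a weaker inhibitor. Compound 1 gives 310 nM, compound 2 gives 820 nM and compound 3 gives 1210 nM. Compound 1 and compound 2 differ in one place only, (4-bromo-2-fluorophenyl in place of 3-chloro-4-fluorophenyl on an aromatic nitrogen), and this change made the step of a 2.6-fold higher number from compound 1 to compound 2 (0.42 log units; beyond the scatter). Compound 3 and compound 1 carry the same group on the aromatic nitrogen but are built on cores that differ elsewhere; that difference between the two cores is not broken down here. Compound 3 stands at the highest of the three numbers, though against compound 2 the gap lies within the scatter.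

Compound 4, `Cn1ccc2c(Oc3ccc(NC(=O)c4cc5cccnc5n(-c5ccc(Br)cc5F)c4=O)cc3)ccnc21`, is not yet measured. Going by the values given here, it differs from compound 3 as 4-bromo-2-fluorophenyl in place of 3-chloro-4-fluorophenyl on an aromatic nitrogen, the same kind of change as the one that separates compound 2 from compound 1, at the same described place. Among the compounds with values here, on the core of compound 1 this change gave a 2.6-fold higher number from compound 1 to compound 2 (0.42 log units; beyond the scatter), and that single observed step is the only guide available; there is no second occurrence on the core of compound 3 to show whether the size carries over. In this assay compound 4 is therefore expected to show a step of about a 2.5-fold higher number from compound 3 to compound 4 (0.39 log units; beyond the scatter) from compound 3, resting on compound 1 and compound 2 with a 2.6-fold higher number from compound 1 to compound 2 (0.42 log units; beyond the scatter). The estimate for compound 4 is 3000 nM, expected to fall between 1400 nM and 6500 nM.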

Compound 4, half-maximal inhibitory concentration: 2580 nM
Compound 4: the middle estimate sits 1.2-fold (0.07 log units) above what was measured, within the range that was stated.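

In this assay, 4-bromo-2-fluorophenyl in place of 3-chloro-4-fluorophenyl on the aromatic nitrogen gives a 2.1-fold higher number from compound 3 to compound 4 (0.33 log units; beyond the scatter), so the change moves the number the same way on the core of compound 3 as on the core of compound 1. The two steps also match in size, and on these two cores the change behaves as a roughly constant increment: the same change on two cores in this assay, a 2.6-fold higher number (0.42 log units; beyond the scatter) from compound 1 to compound 2 and a 2.1-fold higher number (0.33 log units; beyond the scatter) from compound 3 to compound 4, 1.2-fold (0.09 log units) apart, within the scatter of two such steps This supports carrying the step from one of these cores to the other for this one pair of groups, but it rests on two pairs of compounds in a single cell assay, gives no reason for the step, and does not show that it would hold on any further core.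

The change swaps one halogen and alters the substitution pattern in the same move, so the compounds shown leave open which part of it accounts for the step, and how much of the gap between the two cores comes from each point at which they differ. Also open, from the compounds shown here alone, is whether the step would persist if the aromatic nitrogen carried a group other than a halogenated phenyl, such as a phenyl bearing a methoxy group or an amine, or a longer alkyl chain.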